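The source may report more compounds than this note shows. Statements on the series, on what has been measured and on what is new or still open speak of the compounds shown alone.

Measured in an ADME assay on Vero cells (Chlorocebus sabaeus) for cytotoxicity; on this read-out lower numbers stand for higher toxicity in this test and higher numbers for lower toxicity in this test:

Compound 1 `COc1ccc(-c2nc3cc(C(C)=O)ccc3[nH]2)c(OC)c1` gives > 100000 nM, a limit of the assay and not a number.
Compound 2 `COc1cc(OC)cc(-c2nc3cc(C(F)(F)F)ccc3[nH]2)c1` gives > 100000 nM, likewise a limit.
Compound 3 `COc1ccc(-c2nc3cc(C(C)=O)ccc3[nH]2)c(OC)c1OC` gives > 100000 nM, again a limit.

From compound 1 to compound 3 the change is methoxy in place of hydrogen on an aromatic carbon; the step that the two limits leave unreadable from compound 1 to compound 3 cannot be read because of the limit of > 100000 nM in this assay, at which 3 of the 3 values shown sit. Compound 2 and compound 1 differ in their cores, and that difference is not broken down here. Compound 4 `COc1cc(-c2nc3cc(C(F)(F)F)ccc3[nH]2)cc(OC)c1OC` is not yet measured; from compound 2 it differs by methoxy in place of hydrogen on an aromatic carbon, the same kind of change as from compound 1 to compound 3, the place being para rather than meta to a large group. Going by the values given here, with every value so far resting at the limit, this assay is expected to report compound 4 again at or beyond that limit, the expected step being a step that the limit leaves unreadable from compound 2 to compound 4, resting on compound 2 at > 100000 nM. Compound 4 is estimated at 150000 nM, between 80000 nM and 300000 nM.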

Compound 4, half-maximal cytotoxic concentration: 29000 nM
For compound 4 the middle estimate is 5.2-fold (0.71 log units) above the measured one, and the stated range ends above it.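

In this assay, methoxy in place of hydrogen on an aromatic carbon, here para to a large group and ortho to two methoxy groups, gives an at least 3.4-fold lower number from compound 2 to compound 4 (0.53 log units; beyond the scatter), so on the core of compound 2 the change moves the read-out towards higher toxicity in this test. Compound 2 gives > 100000 nM, a limit of the assay and not a number. The same kind of change on the core of compound 1 cannot be read, so carry-over from one core to the other is not shown: the limit of > 100000 nM in this assay, at which 3 of the 4 values shown sit.

Open, on these data alone, is whether the step needs the two ortho methoxy groups. Also open, as far as these compounds go, is whether an amine or a carboxylic acid entering at the same place would move the read-out as methoxy does.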